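Swapping a Carbamoyl Group for a Sulfamoyl Group

The source may hold more compounds than are shown below. What is called first, only, known or untested is meant among the compounds shown, and "the series" means these compounds.

Measured so far in a functional assay on NT2 cells (Homo sapiens) for inhibition; on this read-out lower numbers stand for stronger inhibition and higher numbers for weaker inhibition:
- compound 1 `O=C(O)C[C@H](NC(=O)c1cncc(S(=O)(=O)NC2CC2)c1)C(=O)Oc1ccccc1`: 4300 nM
- compound 2 `CC(C)CN(CC(C)C)C(=O)c1cncc(C(=O)N[C@@H](CC(=O)O)C(=O)CSCc2ccc(F)cc2)c1`: 39000 nM
- compound 3 `O=C(O)C[C@H](NC(=O)c1cncc(S(=O)(=O)NC2CC2)c1)C(=O)COC(=O)c1cccc2ccccc12`: 1300 nM

Of these three, compound 2 has the highest number and so the weakest inhibition, and the gaps to the other two lie beyond the usual scatter. Compound 1 and compound 3 both show lower numbers, but each differs from compound 2 in more than one place. No single structural change can therefore be read from these values.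

Compound 4 `CN(C)S(=O)(=O)c1cncc(C(=O)N[C@@H](CC(=O)O)C(=O)CSCc2ccc(F)cc2)c1` keeps the rest of compound 2, with dimethylsulfamoyl in place of diisobutylcarbamoyl on an aromatic carbon. Among the measured compounds shown here, the only guide to this change is indirect. Compound 1 also carries a sulfonamide group and gives 4300 nM, while compound 3 carries one too and gives 1300 nM. On that slim basis, a move towards a lower number in this assay is expected, probably beyond the scatter, though the other differences among these compounds keep this uncertain. The expected change is a 4.3-fold lower number from compound 2 to compound 4 (0.64 log units; beyond the scatter). The estimate for compound 4 is 9000 nM, with an expected range of 2500 nM to 32000 nM.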

Compound 4, half-maximal inhibitory concentration: 21000 nM
Compound 4: the middle estimate sits 2.3-fold (0.37 log units) below what was measured; low and high end bracket the measured number.
By their numbers in this assay, from the lowest: compound 3; then compound 1; then compounds 4 and 2 (each within the scatter of the next).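

In this assay, replacing diisobutylcarbamoyl with dimethylsulfamoyl on this aromatic carbon, two atoms from the ring nitrogen, gives a 1.9-fold lower number from compound 2 to compound 4 (0.27 log units; within the scatter), so the two compounds cannot be told apart on this read-out. Among the compounds shown here, this is the first direct reading at this position: with the rest of the molecule held constant, a group of 6 heavy atoms and one of 11 heavy atoms give numbers within the scatter of each other, and the sulfamoyl group brings no measurable gain in this setting. No measurement here explains why the swap makes so little difference to the number.

This single step changes two things at once, the carbonyl link becoming a sulfonyl link and the isobutyl groups becoming methyl groups, so dimethylcarbamoyl and diisobutylsulfamoyl would be the groups needed to separate those two contributions. Going by these compounds, it also remains open whether a quite different group on this carbon, such as an amine or a carboxylic acid, would move the number beyond the scatter, and whether this swap would give a similar result on other parts of the series.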